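This account rests on a few compounds, and the source may have more. Where it says the series, first, only, none or still open, it means among the compounds named here.

Series notes, cytotoxicity set.

Three compounds of the shared core are measured. Compound 2 `CN1CCC(NC(=O)c2ccc(Nc3ncc(Br)c(NC4CCCC4)n3)cc2)CC1` gives 2400 nM in a functional assay on HepG2 cells (Homo sapiens) for cytotoxicity, read by MTT assay, with a stated time of 48 h; a lower number here means a stronger inhibitor, a higher number a weaker inhibitor. Compound 1 `COc1cc(C(=O)NC2CCN(C)CC2)ccc1Nc1ncc(Br)c(NC2CCCC2)n1` gives 4900 nM in this assay; the change from compound 2 to compound 1 is methoxy in place of hydrogen on an aromatic carbon and it made a 2.0-fold higher number from compound 2 to compound 1 (0.31 log units; beyond the scatter). Compound 3 `CN1CCC(NC(=O)c2ccc(Nc3ncc(F)c(NC4CCCC4)n3)cc2)CC1` gives 10000 nM in this assay; here the change is fluoro in place of bromo on an aromatic carbon and the step is a 4.2-fold higher number from compound 2 to compound 3 (0.62 log units; beyond the scatter). Compound 3 thus sits at the highest of the three numbers, with compound 1 nearest and compound 2 furthest.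

Compound 4 `COc1cc(C(=O)NC2CCN(C)CC2)ccc1Nc1ncc(F)c(NC2CCCC2)n1` is not yet measured in this assay. It differs from compound 3 by methoxy in place of hydrogen on an aromatic carbon. This is the same change as that from compound 2 to compound 1, occurring twice in the set, and the place is the same word for word; the two cores differ by fluoro in place of bromo on an aromatic carbon. Going by the values given here, the step from compound 3 to compound 4 in this assay is expected to be a 1.8-fold higher number from compound 3 to compound 4 (0.26 log units; within the scatter), close to the earlier one, because the only precedent is a 2.0-fold higher number from compound 2 to compound 1 (0.31 log units; beyond the scatter) on the core of compound 2. Compound 4 is therefore estimated at 18000 nM, with a range from 9000 nM to 40000 nM, and the weakly inhibiting starting point of compound 3 makes a reported limit rather than a number quite possible.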

Compound 4, half-maximal inhibitory concentration: 4500 nM
Beside the measured number, compound 4's estimate is 4.0-fold (0.60 log units) above it, outside the stated range (below it).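

Methoxy in place of hydrogen does not carry over from one core to the other in this assay; on the fluoro core it gives a 2.2-fold lower number from compound 3 to compound 4 (0.35 log units; beyond the scatter), and the direction differs from that on the bromo core: the same change on two cores in this assay, a 2.0-fold higher number (0.31 log units; beyond the scatter) from compound 2 to compound 1 and a 2.2-fold lower number (0.35 log units; beyond the scatter) from compound 3 to compound 4, 4.5-fold (0.66 log units) apart, beyond the scatter of two such steps. Seen from the other side of the same four compounds, fluoro in place of bromo on the methoxy-bearing core gives a 1.1-fold lower number from compound 1 to compound 4 (0.04 log units; within the scatter), which is within the scatter and does not repeat the earlier step: the same change on two cores in this assay, a 4.2-fold higher number (0.62 log units; beyond the scatter) from compound 2 to compound 3 and a 1.1-fold lower number (0.04 log units; within the scatter) from compound 1 to compound 4, 4.5-fold (0.66 log units) apart, beyond the scatter of two such steps. This shows that in this series the effect of each change depends on the core carrying it, so a step from one core is a poor guide to the other, but it rests on a single set of four compounds and does not show why the steps differ or how they would behave on any further core.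

Still open, from the compounds shown here alone, is whether this dependence holds with chloro in place of bromo or with ethoxy in place of methoxy. Also open, going by these compounds, is whether it survives a carboxylic acid in place of the (1-methylpiperidin-4-yl)carbamoyl group.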